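Benzoyloxy for propyl on the dihydropyridine side chain

The source may report more compounds than this note shows. Statements on the series, on what has been measured and on what is new or still open speak of the compounds shown alone.

Compound 1 `CCCCC1=C(C(=O)OCC)C(c2cccc([N+](=O)[O-])c2)C(C(=O)OCC)=C(C)N1` is the reference point of this short set. In a functional assay on HEK293 cells for antagonist activity at Voltage-dependent L-type calcium channel subunit alpha-1C (Oryctolagus cuniculus), read by FLIPR (on this read-out higher numbers stand for weaker inhibition and lower numbers for stronger inhibition), compound 1 gives 20 nM, the lowest of the two numbers available. The only comparator, compound 2 `COCC1=C(C(=O)OC)C(c2cccc([N+](=O)[O-])c2)C(C(=O)OC)=C(C)N1`, gives 115 nM in this assay, a step well beyond the scatter; compound 2 differs from compound 1 in more than one place, so no single-change step can be read from it.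

Compound 3 `CCOC(=O)C1=C(C)NC(COC(=O)c2ccccc2)=C(C(=O)OCC)C1c1cccc([N+](=O)[O-])c1` is not yet measured. It differs from compound 1 by benzoyloxy in place of propyl on a saturated chain carbon bound to a double-bonded ring carbon. Within the data shown here, there is no measured pair in the set that isolates this change, so the expectation rests on compound 1 alone and on the observation that this series keeps a low number while the saturated chain carbon bound to the double-bonded ring carbon carries different groups. The step from compound 1 to compound 3 is expected to be small, on the weaker side if anything, and may well stay within the scatter: a 1.8-fold higher number from compound 1 to compound 3 (0.24 log units; within the scatter). For compound 3 the estimate in this assay is 35 nM, with a range from 8 nM to 150 nM.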

Compound 3, half-maximal inhibitory concentration: 210 nM
Beside the measured number, compound 3's estimate is 6.0-fold (0.78 log units) below it, outside the stated range (above it).
By their numbers in this assay, from the lowest: compound 1; then compounds 2 and 3 (each within the scatter of the next).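

In this assay, among these compounds, benzoyloxy in place of propyl on a saturated chain carbon bound to a double-bonded ring carbon gives an 11-fold higher number from compound 1 to compound 3 (1.02 log units; beyond the scatter), the first single-change step in this set, and it shows that this position does not take every group without a clear loss of inhibition. The change is a composite one: cut one bond further out, it reads butyl to (benzoyloxy)methyl, and the entering group brings a six-membered aromatic ring of carbon only and 2 hydrogen-bond acceptors, so this one step cannot assign the shift to any single part of that group. Nothing available gives a cause for the step, and the steps involving compound 2 cannot be read, as compound 2 differs from the others in more than one place.

As far as these compounds go, it remains open whether the loss follows the aromatic ring, the ester link or simply the size of the entering group. An acetoxy group, a benzyloxy group or an amine on the same saturated chain carbon would separate these readings, and a longer alkyl chain would show how far the low number of compound 1 extends.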